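Widening a Saturated Ring on a Shared Core

The source may hold more compounds than are shown below. What is called first, only, known or untested is meant among the compounds shown, and "the series" means these compounds.

Compound 1 `CNC(=O)c1cc(Oc2ccc(Nc3nccc(N4CCCC4)n3)cc2)ccn1`: 46.6%
Compound 2 `CN(c1ccc(Oc2ncnc3ccsc23)cc1)c1nccc(N2CCc3ccccc3C2)n1`: 30.2%

Of the compounds shown here, two have numbers so far. In a functional assay on MDA-MB-231 cells (Homo sapiens) for inhibition, read by MTT assay, with a stated time of 72 h, tested at 20 uM (on this read-out lower numbers stand for less inhibition and higher numbers for more inhibition at the one concentration tested (going by the name of the read-out)), compound 1 gives 46.6%. In this assay compound 2 gives 30.2%. Of these two numbers, compound 1 stands highest. Its gap to compound 2 lies beyond the usual scatter of repeated measurements. The two structures differ in many places at once, so nothing about any single change can be read from that gap.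

Compound 3 `CNC(=O)c1cc(Oc2ccc(Nc3nccc(N4CCCCC4)n3)cc2)ccn1` differs from compound 1 in one place only: piperidin-1-yl in place of pyrrolidin-1-yl on an aromatic carbon. The saturated ring grows by one carbon; the count of hydrogen-bond donors and acceptors stays the same, and the charge stays neutral.

Within the data shown here, no measured pair differing in exactly this way is available, so the size of this step is not known from the data. The step is expected to be small, and in this assay the change from compound 1 to compound 3 is expected to be none beyond the scatter, a number 1.6 percentage points lower from compound 1 to compound 3 (within the scatter). Compound 3 is therefore estimated at 45%, with an expected range from 25% to 65%.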

Compound 3, a percentage reported as inhibition, at one concentration (the size of the read-out at that concentration, not a potency): 52.3%
Compound 3: middle estimate off by 7.3 percentage points, on the low side; measured number inside the range.
By their numbers in this assay, from the lowest: compound 2; then compounds 1 and 3 (each within the scatter of the next).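

Among these compounds, this is the first change that can be read on its own, since compounds 1 and 3 differ only in the saturated ring on the aromatic carbon next to the ring nitrogen. In this assay, piperidin-1-yl in place of pyrrolidin-1-yl gives a number 5.7 percentage points higher from compound 1 to compound 3 (within the scatter), so on this core and at this position, the six-membered non-aromatic ring and the five-membered one cannot be told apart by this read-out. Among the compounds shown here, no separate measurement bears on this pair, so the data offer no account of the step.

For the compounds shown here, this single pair, read at a single concentration, shows only that these two rings give numbers within the scatter of each other, and it says nothing about potency. On these data alone, how far the position stays this forgiving remains open for a larger ring such as azepan-1-yl, a ring with a second hetero atom such as morpholin-4-yl or piperazin-1-yl, or an open-chain amine such as diethylamino.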